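The source may report more compounds than this note shows. Statements on the series, on what has been measured and on what is new or still open speak of the compounds shown alone.

Working notes on the series in an ADME assay on Karpas-1106P cells (Homo sapiens) for cytotoxicity; a lower number here means that less compound is needed, a higher number that more compound is needed for the effect.

Compound 1 `Cc1ccc(S(=O)(=O)N[C@@H](CC(=O)NC(C)(C)C)C(=O)NCCNC(=O)c2cc(C)ccc2F)cc1` gives in this assay only a limit, > 11100 nM. Compound 2 `Cc1ccc(S(=O)(=O)N[C@@H](CC(=O)NC(C)(C)C)C(=O)NCCNC(=O)c2ccccc2)cc1` gives in this assay only a limit, > 11100 nM. Compound 3 `Cc1ccc(S(=O)(=O)N[C@@H](CC(=O)NC(C)(C)C)C(=O)NCCNC(=O)Nc2ccccc2)cc1` gives in this assay only a limit, > 11100 nM. On the numbers shown, compound 3 stands at the same limit as the other two compounds of the shared core; no number separates them.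

The steps a step that the two limits leave unreadable from compound 1 to compound 2, a step that the two limits leave unreadable from compound 1 to compound 3 and a step that the two limits leave unreadable from compound 2 to compound 3 are therefore of unknown size because of the limit of > 11100 nM in this assay, at which 3 of the 3 values shown sit. For the measured compounds named here, none of the measured steps carries a readable size that could bear on the change to compound 4.

Compound 4 `Cc1ccc(S(=O)(=O)N[C@@H](CC(=O)NC(C)(C)C)C(=O)NCCNC(=O)c2cc(Cl)ccc2Cl)cc1` differs from compound 3 in one place: 2,5-dichlorophenyl in place of anilino on a carbonyl carbon. With three changes of the group on the carbonyl carbon having left the read-out at the limit, compound 4 is expected to remain there too, so the expected step is a step that the limit leaves unreadable from compound 3 to compound 4 with no direction readable. For compound 4 the estimate in this assay is 20000 nM, within a range from 7000 nM to 60000 nM, most likely reported again only as a limit.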

Compound 4, half-maximal effective concentration: > 11100 nM
Compound 4 was reported as a limit; the forecaster's own chance of this, stated with the estimate: 85%; the middle value does not contradict the limit.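

In this assay compound 4 gives only a limit, > 11100 nM. The steps linking compound 4 with compound 1, compound 2 and compound 3 cannot be read because all four compounds share one limit: the limit of > 11100 nM in this assay, at which 4 of the 4 values shown sit.

The compounds shown leave open whether any of these groups on the carbonyl carbon changes the read-out at all.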